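A few compounds are considered here, and "the series" means these few. Any claim that something is new, unique, unknown or untested is made for them only; others in the source may bear on it.

Measured compounds:
- compound 1, `O=C(O)c1ccccc1-c1ccc(CCc2ncc(Cc3ccccc3Cl)[nH]2)cc1`, gives 292 nM
- compound 2, `N#Cc1ccc(Cc2cnc(CCc3ccc(-c4ccccc4C(=O)O)cc3)[nH]2)cc1`, gives 5890 nM
- compound 3, `CC(C)(C)Cc1cnc(CCc2ccc(-c3ccccc3C(=O)O)cc2)[nH]1`, gives 106 nM

All three share one core and differ only in the group on a saturated chain carbon bound to an aromatic carbon. In an in vitro functional assay on cells for agonist activity at Bombesin receptor subtype-3 (Homo sapiens), read by luminescence and calcium flux (on this read-out lower numbers stand for an effect already at smaller amounts and higher numbers for an effect only at larger amounts of compound), compound 3 stands lowest of the three numbers; its nearest neighbour is compound 1, at a 2.8-fold lower number from compound 1 to compound 3 (0.44 log units; beyond the scatter), and the furthest is compound 2, at a 56-fold lower number from compound 2 to compound 3 (1.74 log units; beyond the scatter). Compound 4, `O=C(O)c1ccccc1-c1ccc(CCc2ncc(CC3CCCCCC3)[nH]2)cc1`, has not yet been measured. It differs from compound 3 by cycloheptyl in place of tert-butyl on a saturated chain carbon bound to an aromatic carbon.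

The two measured steps that lead to compound 3 both replace an aromatic group by tert-butyl and both lower the number, one modestly and one strongly. Neither step swaps one saturated group for another, so the data give no direct guide to tert-butyl against cycloheptyl. Since both saturated groups sit where tert-butyl already gave the lowest number, a step of a 1.3-fold lower number from compound 3 to compound 4 (0.12 log units; within the scatter) is expected, that is little change or a slightly lower number. Compound 4 is therefore estimated at 80 nM, with a range from 25 nM to 300 nM.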

Compound 4, half-maximal effective concentration: 88 nM
Beside the measured number, compound 4's estimate is 1.1-fold (0.04 log units) below it; the range from low to high includes it.
By their numbers in this assay, from the lowest: compounds 4 and 3 (each within the scatter of the next); then compound 1; then compound 2.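

In this assay, within the data shown here, cycloheptyl in place of tert-butyl gives a 1.2-fold lower number from compound 3 to compound 4 (0.08 log units; within the scatter), the first comparison here of two saturated groups, and it shows that 7 heavy atoms in one ring of carbon serve this position as well as 4 heavy atoms in a branched group without a ring. The separation from the aromatic groups also holds for this second saturated group, with a 3.3-fold lower number from compound 1 to compound 4 (0.52 log units; beyond the scatter) and a 67-fold lower number from compound 2 to compound 4 (1.83 log units; beyond the scatter), so both saturated compounds, compound 3 and compound 4, stand apart from the 2-chlorophenyl and 4-cyanophenyl compounds. No available evidence bears on the reason for this result.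

The compounds shown leave open whether a smaller ring such as cyclopropyl would keep the number as low. They also leave open what an amine or a hydroxyl on the saturated group would do.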